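The compounds below may be only part of what the source reports. "The series", "measured", "known", "first", "only" and "open" are said of these compounds alone.

Measured in a functional assay on DU-145 cells (Homo sapiens) for cytotoxicity, read by MTT assay; on this read-out lower numbers stand for stronger inhibition and higher numbers for weaker inhibition:
compound 1 `COC(C)CO[C@H](CC=C(C)C)C1=CC(=O)c2c(O)ccc(O)c2C1=O` gives 16600 nM
compound 2 `CC[C@](C)(O)CC(=O)O[C@H](CC=C(C)C)C1=CC(=O)c2c(O)ccc(O)c2C1=O` gives 20500 nM
compound 3 `CC(C)=CC[C@@H](OCC(C)O)C1=CC(=O)c2c(O)ccc(O)c2C1=O` gives 16100 nM

Compound 3 stands level with the other two compounds. The data show a 1.0-fold lower number from compound 1 to compound 3 (0.01 log units; within the scatter) and a 1.3-fold lower number from compound 2 to compound 3 (0.10 log units; within the scatter), so no separation among them can be claimed.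

The next compound, compound 4 `CC(C)=CC[C@@H](OC(=O)CC(C)(O)C(C)C)C1=CC(=O)c2c(O)ccc(O)c2C1=O`, carries (2-hydroxy-2,3-dimethylbutyl)carbonyl in place of 2-hydroxypropyl on an oxygen on a saturated carbon. The difference from compound 3 counts as follows: (2-hydroxy-2,3-dimethylbutyl)carbonyl in place of 2-hydroxypropyl on an oxygen on a saturated carbon.

For the measured compounds named here, two measured steps bear on this change. The closest is the one that replaces (2-hydroxy-2-methylbutyl)carbonyl with 2-hydroxypropyl at that same place, a 1.3-fold lower number from compound 2 to compound 3 (0.10 log units; within the scatter), which runs in the opposite direction to the change at hand. The other puts (2-hydroxy-2-methylbutyl)carbonyl in place of 2-methoxypropyl, a 1.2-fold higher number from compound 1 to compound 2 (0.09 log units; within the scatter). Both are small, and neither leaves the scatter. Going by the values given here, no measured compound carries the (2-hydroxy-2,3-dimethylbutyl)carbonyl group itself, so the estimate rests on these related steps alone.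

In this assay, no shift beyond the scatter is therefore expected, and the estimated step is a 1.2-fold higher number from compound 3 to compound 4 (0.07 log units; within the scatter). The value expected for compound 4 is 19000 nM, with an estimated range from 10000 nM to 35000 nM.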

Compound 4, half-maximal inhibitory concentration: 16900 nM
For compound 4 the middle estimate is 1.1-fold (0.05 log units) above the measured one; measured number inside the range.
By their numbers in this assay, from the lowest: compounds 3, 1, 4 and 2 (each within the scatter of the next).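

In this assay, putting (2-hydroxy-2,3-dimethylbutyl)carbonyl in place of 2-hydroxypropyl on the oxygen on a saturated carbon gives a 1.0-fold higher number from compound 3 to compound 4 (0.02 log units; within the scatter) and so adds a larger group at this position without moving the number out of the scatter. For the compounds shown here, the first comparison confined to the far end of the acylated chain, 1-hydroxy-1,2-dimethylpropyl in place of 1-hydroxy-1-methylpropyl on a saturated chain carbon bound to a carbonyl carbon, gives a 1.2-fold lower number from compound 2 to compound 4 (0.08 log units; within the scatter) and shows that this added branch also leaves this assay level, while the exchange against 2-methoxypropyl gives a 1.0-fold higher number from compound 1 to compound 4 (0.01 log units; within the scatter) and likewise stays within the scatter. Nothing available here explains why these different groups give level numbers.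

The four compounds therefore show no group at this oxygen that separates from the others, and they leave open whether any substituent here can shift the number at all. In particular, they do not tell whether an amine, a carboxylic acid or a phenyl ring at the end of this chain would give a step beyond the scatter in this assay or stay level with these compounds.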